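Fluoro for chloro: two parallel steps in a small series

The source may hold more compounds than are shown below. What is called first, only, known or untested is meant among the compounds shown, and "the series" means these compounds.

compound 1 `O=C(OCc1ccccc1)N1CCN(C(=S)SCc2cn(Cc3ccc(Cl)cc3)nn2)CC1`: > 128000 nM, a limit only
compound 2 `O=C(OCc1ccccc1)N1CCN(C(=S)SCc2cn(Cc3ccc(F)cc3)nn2)CC1`: 32000 nM
compound 3 `S=C(SCc1cn(Cc2ccccc2Cl)nn1)N1CCNCC1`: > 128000 nM, a limit only

In a functional assay on ECa-109 cells (Homo sapiens) for inhibition, read by MTT assay, with a stated time of 72 h (a higher number here means a weaker inhibitor, a lower number a stronger inhibitor), compound 1 reaches only a limit, (the limit of > 128000 nM in this assay, at which 2 of the 3 values shown sit). Compound 3 likewise stops at that limit. The difference between the cores of compound 1 and compound 3 is not broken down here. Among the measured compounds shown here, the one counted change, (fluoro in place of chloro on an aromatic carbon), gives an at least 4.0-fold lower number from compound 1 to compound 2 (0.60 log units; beyond the scatter).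

Compound 4 `Fc1ccccc1Cn1cc(CSC(=S)N2CCNCC2)nn1` is not yet measured. Its change from compound 3, (fluoro in place of chloro on an aromatic carbon), is the same kind of change as in compound 2, but the place differs: ortho to a large group here, para to a large group there. Compound 4 is expected to give an at least 1.4-fold lower number from compound 3 to compound 4 (0.15 log units; that floor lies within the scatter), resting on the step compound 1 to compound 2, an at least 4.0-fold lower number from compound 1 to compound 2 (0.60 log units; beyond the scatter), while the start in compound 3 is only a limit, > 128000 nM. The estimate for compound 4 is 90000 nM, between 25000 nM and 300000 nM.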

Compound 4, half-maximal inhibitory concentration: > 128000 nM
Compound 4: only a limit was reported; the forecaster's own chance of this, stated with the estimate: 45%; at least 1.4-fold (0.15 log units) between middle value and limit.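

Compound 3 and compound 4 both stop at a limit, so no step between them can be read: the limit of > 128000 nM in this assay, at which 3 of the 4 values shown sit.

Still open, from the compounds shown here alone, is whether 2-fluorophenyl in place of 2-chlorophenyl changes the reading at all on the core shared by compound 3 and compound 4.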